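The source may report more compounds than this note shows. Statements on the series, on what has been measured and on what is new or still open speak of the compounds shown alone.

Measured so far:
compound 1, `COC(=O)c1ccc(NCc2cncn2Cc2ccc(C(C)(C)C)cc2)cc1-c1ccccc1`: "not determined" (no result reported)
compound 2, `COC(=O)c1ccc(NCc2cncn2Cc2cccc(F)c2)cc1-c1ccccc1`: > 1000 nM

In a toxicity assay on NIH3T3 cells (Mus musculus) for cytotoxicity, read by resazurin assay (a higher number here means that more compound is needed for the effect, a lower number that less compound is needed), compound 2 returns only a limit, > 1000 nM, not a number. Compound 1 has no result in this assay. Going by the values given here, compound 2 therefore sits at the limit of > 1000 nM in this assay, at which 1 of the 2 values shown sits, and no step between measured compounds can be drawn.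

Compound 3, `COC(=O)c1ccc(NCc2cncn2Cc2cccc([N+](=O)[O-])c2)cc1-c1ccccc1`, differs from compound 2 by nitro in place of fluoro on an aromatic carbon. Among the compounds with values here, with no measured step, the step that the limit leaves unreadable from compound 2 to compound 3 is expected to be none beyond the scatter. Compound 3 is accordingly estimated at 3000 nM, within 800 nM to 20000 nM, most likely again reported as a limit.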

Compound 3, half-maximal effective concentration: > 10000 nM
Compound 3: only a limit was reported (the forecaster's own chance of this, stated with the estimate: 70%); middle value at least 3.3-fold (0.52 log units) away from the limit.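

In this assay compound 2 gives only a limit, > 1000 nM. Going by these compounds alone, compound 3 also gives only a limit, > 10000 nM, so no step between the two can be read. Open: where the actual half-maximal effective concentration of either compound lies in this assay.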